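Swapping furan for thiophene on a dihydropyrimidinone core

The compounds below may be only part of what the source reports. "The series", "measured", "known", "first", "only" and "open" are said of these compounds alone.

The four compounds share a six-membered non-aromatic ring with two nitrogens carrying a five-membered aromatic group on a saturated ring carbon. Compound 1 `CC1=C(C(=O)OC(C)(C)C)C(c2ccoc2)NC(=O)N1` carries furan-3-yl there, and compound 2 `CC1=C(C(=O)OC(C)(C)C)C(c2cccs2)NC(=O)N1` carries thiophen-2-yl; the two differ only in this way, (thiophen-2-yl in place of furan-3-yl on a saturated ring carbon). In an assay on membranes from CHO cells for displacement of a labelled ligand from adenosine receptor A1 (Homo sapiens), read by scintillation counting, with a stated time of 60 min, tested at 1 uM (a lower number here means less inhibition, a higher number more inhibition at the concentration tested (going by the name of the read-out)), compound 1 gives 11%, and compound 2 gives 26%, so that a number 15 percentage points higher from compound 1 to compound 2 (beyond the scatter).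

Compound 3 `COC(=O)C1=C(C)N(C)C(=O)NC1c1ccoc1` has a different core, one that bears a methoxycarbonyl group and a methyl group on the ring nitrogen; how its core differs from that of compound 1 is not broken down here. In this assay compound 3 gives 15%, which sits within the usual scatter of the number for compound 1.

Compound 4 `COC(=O)C1=C(C)N(C)C(=O)NC1c1cccs1` is to compound 3 what compound 2 is to compound 1: thiophen-2-yl in place of furan-3-yl on a saturated ring carbon. The surroundings are not identical word for word, since in compound 4 the changed carbon is "next to the ring atom that bears a methoxycarbonyl group" and "three ring bonds from the ring atom that bears a methyl group", whereas in compound 2 it is "next to the ring atom that bears a group of 7 heavy atoms"; it is the same kind of change, not the same change. Because a number 15 percentage points higher from compound 1 to compound 2 (beyond the scatter), the step of a number 15 percentage points higher from compound 3 to compound 4 (beyond the scatter) is expected to be of similar size. Compound 4 is therefore estimated at 30% in this assay, most likely between 15% and 45%.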

Compound 4, a percentage reported as inhibition, at one concentration (the size of the read-out at that concentration, not a potency): 30%
Compound 4: middle estimate and measured number agree at the digits printed; measured number inside the range.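

In this assay, the swap of furan-3-yl for thiophen-2-yl on the saturated ring carbon gives a number 15 percentage points higher from compound 3 to compound 4 (beyond the scatter), so the second core responds in the same direction as the first. Set side by side, the two steps do not differ: the same change on two cores in this assay, a number 15 percentage points higher (beyond the scatter) from compound 1 to compound 2 and a number 15 percentage points higher (beyond the scatter) from compound 3 to compound 4, 0 percentage points apart, within the scatter of two such steps. This shows that, for these two pairs, the change carries over from one core to the other with its size intact, but two pairs make no rule for other cores, and the numbers give no reason why the step occurs or why it is the same on both cores; each number is also the size of the read-out at one concentration, not a potency.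

The compounds shown leave open whether the step follows from sulfur replacing oxygen or from the different point of attachment of the ring, a question that furan-2-yl or thiophen-3-yl on the same carbon could help to separate. Also open, going by these compounds, is whether the step would stay the same on a core carrying a carboxylic acid or an amide in place of the ester, or with a longer chain on the ring nitrogen.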